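The source may report more compounds than this note shows. Statements on the series, on what has been measured and on what is new or still open speak of the compounds shown alone.

Measured so far in a functional assay on CHO-K1 cells for agonist activity at somatostatin receptor type 2 (Homo sapiens), read by cAMP accumulation, with a stated time of 30 min; a lower number here means that less compound is needed, a higher number that more compound is needed for the effect:
- compound 1 `Cc1cc(C)cc(CNc2cncc(-c3cc(C)cc(C)c3)c2N2CCC(N)CC2)c1`: 0.8 nM
- compound 2 `Cc1cc(C)cc(C(=O)Nc2cncc(-c3cc(C)cc(C)c3)c2N2CCC(N)CC2)c1`: 0.04 nM

Compound 1 holds the highest of the two numbers; its nearest neighbour is compound 2, reached by a 20-fold lower number from compound 1 to compound 2 (1.30 log units; beyond the scatter). That step touched only the linker on the nitrogen of the shared core, (3,5-dimethylphenyl)carbonyl in place of 3,5-dimethylbenzyl, and it moved this assay by a large amount.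

Compound 3 `Cc1cc(C)cc(OCc2cncc(-c3cc(C)cc(C)c3)c2N2CCC(N)CC2)c1` is not yet measured. It differs from compound 1 at the same side of the core: (3,5-dimethylphenoxy)methyl in place of (3,5-dimethylbenzyl)amino on an aromatic carbon. The change again rewrites the linker between the core and the 3,5-dimethylphenyl ring, now removing the hydrogen-bond donor rather than adding a carbonyl. Among the measured compounds shown here, the only step that bears on it is the one from compound 1 to compound 2, and it shows that this linker is a sensitive spot, but it points in no direct way to an ether. For the measured compounds named here, no measured pair covers an oxygen linker, so the expectation rests on compound 1 alone.

Compound 3 is expected to give 2 nM (range 0.3 nM to 15 nM), a step of a 2.5-fold higher number from compound 1 to compound 3 (0.40 log units; beyond the scatter) that is estimated to stay close to compound 1.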

Compound 3, half-maximal effective concentration: 3.7 nM
Beside the measured number, compound 3's estimate is 1.9-fold (0.27 log units) below it, within the range that was stated.
By their numbers in this assay, from the lowest: compound 2; then compound 1; then compound 3.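

In this assay, putting (3,5-dimethylphenoxy)methyl in place of (3,5-dimethylbenzyl)amino on the aromatic carbon gives a 4.6-fold higher number from compound 1 to compound 3 (0.67 log units; beyond the scatter), so this position responds in the opposite direction from the earlier change, which gave a 20-fold lower number from compound 1 to compound 2 (1.30 log units; beyond the scatter). The linker therefore moves the number both ways around compound 1 with the 3,5-dimethylphenyl ring retained, and the new step shows a modest shift even though the group keeps its 10 heavy atoms and 1 hydrogen-bond acceptor while going from 1 hydrogen-bond donor to 0 hydrogen-bond donors. The loss of the donor travels together with the exchange of nitrogen for oxygen and the new order of the linker atoms, and no measurement here separates these or gives a reason for the higher number.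

The compounds shown leave open whether the donor itself matters, which a linker such as a methylamino group or a sulfonamide could test. They also leave open whether the linker order counts, as a reversed amide or an ether with its oxygen on the shared core would show, and how a longer chain would behave at this position.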